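The source may report more compounds than this note shows. Statements on the series, on what has been measured and on what is new or still open speak of the compounds shown alone.

Three compounds of the series share one core and differ only in the group carried on an oxygen next to a carbonyl group. Compound 1 `COC(=O)NS(=O)(=O)c1sc(CC(C)C)cc1-c1cccc(Cn2ccnc2)c1` carries methyl there, and in an assay on HEK293 cells for displacement of a labelled ligand from Type-2 angiotensin II receptor (Homo sapiens), read by scintillation counting, with a stated time of 240 min (a higher number here means a weaker inhibitor, a lower number a stronger inhibitor), compound 1 gives 400 nM. Compound 2 `CCC(C)OC(=O)NS(=O)(=O)c1sc(CC(C)C)cc1-c1cccc(Cn2ccnc2)c1` carries sec-butyl, and in this assay compound 2 gives 440 nM. Compound 3 `CC(C)Cc1cc(-c2cccc(Cn3ccnc3)c2)c(S(=O)(=O)NC(=O)OC(C)(C)C)s1` carries tert-butyl, and in this assay compound 3 gives 270 nM, the lowest of the three numbers, although both steps leading to it, a 1.5-fold lower number from compound 1 to compound 3 (0.17 log units; within the scatter) and a 1.6-fold lower number from compound 2 to compound 3 (0.21 log units; within the scatter), stay within the scatter. The step between the two smaller groups, a 1.1-fold higher number from compound 1 to compound 2 (0.04 log units; within the scatter), is within the scatter as well.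

Compound 4 `CC(C)Cc1cc(-c2cccc(Cn3ccnc3)c2)c(S(=O)(=O)NC(=O)OCC2CC2)s1` awaits measurement. Its change from compound 3 is cyclopropylmethyl in place of tert-butyl on an oxygen next to a carbonyl group. All three measured steps bear on this change, since each also exchanges the group on that oxygen, and none of them moved the number beyond the scatter. No step beyond the scatter is therefore expected in this assay for compound 4, in either direction. The expected step is a 1.2-fold higher number from compound 3 to compound 4 (0.09 log units; within the scatter). Compound 4 is estimated at 330 nM in this assay, with a range from 160 nM to 700 nM.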

Compound 4, inhibition constant: 140 nM
The estimate for compound 4 lay 2.4-fold (0.37 log units) above the measured number; measured number below the stated range.
By their numbers in this assay, from the lowest: compounds 4, 3, 1 and 2 (each within the scatter of the next, the first and the last beyond it).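

Within the data shown here, on the oxygen next to a carbonyl group, cyclopropylmethyl gives the first steps in this assay that pass the scatter (a 3.1-fold lower number from compound 2 to compound 4 (0.50 log units; beyond the scatter); a 2.9-fold lower number from compound 1 to compound 4 (0.46 log units; beyond the scatter)), whereas no exchange among methyl, sec-butyl and tert-butyl did so. Against tert-butyl the change stays within the scatter (a 1.9-fold lower number from compound 3 to compound 4 (0.29 log units; within the scatter)), so compound 3 and compound 4 cannot be ordered, although the two groups differ in that cyclopropylmethyl alone brings a three-membered ring at the same count of 4 heavy atoms. No measurement at hand accounts for the separation of compound 4 from compound 1 and compound 2.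

The compounds shown leave open whether the ring matters at all: a straight butyl chain or cyclobutylmethyl on that oxygen would help to settle this. Also open, on these data alone, is how a chain ending in an amine or a carboxylic acid would read at this place.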